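Amide aryl changes on a shared flavonol-type core

A few compounds are considered here, and "the series" means these few. Any claim that something is new, unique, unknown or untested is made for them only; others in the source may bear on it.

Measured compounds:
- compound 1 `COc1ccc(C(=O)Nc2cccc(-c3oc4cc(-c5ccc(F)cc5)ccc4c(=O)c3O)c2)cc1`: in a functional assay on HepG2 cells (Homo sapiens) for antiproliferative activity, read by CCK-8 assay, with a stated time of 72 h (on this read-out lower numbers stand for stronger inhibition and higher numbers for weaker inhibition), compound 1 gives 8420 nM
- compound 2 `Cc1ccc(C(=O)Nc2cccc(-c3oc4cc(-c5ccc(F)cc5)ccc4c(=O)c3O)c2)cc1`: in this assay compound 2 gives 2320 nM
- compound 3 `O=C(Nc1cccc(-c2oc3cc(-c4ccc(F)cc4)ccc3c(=O)c2O)c1)c1ccc(Cl)cc1`: in this assay compound 3 gives 11000 nM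

Compound 3 stands at the highest number of the three. Compound 1 sits close to it, a 1.3-fold higher number from compound 1 to compound 3 (0.12 log units; within the scatter), so the two cannot be ranked against each other. Compound 2 is clearly separated, a 4.7-fold higher number from compound 2 to compound 3 (0.68 log units; beyond the scatter), and likewise a 3.6-fold lower number from compound 1 to compound 2 (0.56 log units; beyond the scatter).

Compound 4 `COc1ccccc1C(=O)Nc1cccc(-c2oc3cc(-c4ccc(F)cc4)ccc3c(=O)c2O)c1` is not yet measured. It differs from compound 3 by 2-methoxyphenyl in place of 4-chlorophenyl on a carbonyl carbon. For the measured compounds named here, the step that bears most directly on this is the one from compound 1 to compound 3, where chloro and methoxy on the aromatic carbon gave numbers within the scatter of each other. Going by the values given here, compound 4 carries its methoxy on a different carbon of that ring, and no measured pair shows what that shift does; the three methoxy, methyl and chloro analogues give no guide to it.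

The expectation for compound 4 is therefore a step from compound 3 of a 1.3-fold lower number from compound 3 to compound 4 (0.11 log units; within the scatter), essentially none beyond the scatter, with a wide range. The estimate for compound 4 is 8500 nM, between 2500 nM and 28000 nM.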

Compound 4, half-maximal inhibitory concentration: 14500 nM
The estimate for compound 4 lay 1.7-fold (0.23 log units) below the measured number; the range from low to high includes it.
By their numbers in this assay, from the lowest: compound 2; then compounds 1, 3 and 4 (each within the scatter of the next).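

In this assay, for the compounds shown here, the shift from 4-methoxyphenyl to 2-methoxyphenyl on the carbonyl carbon, which no earlier pair covered, gives a 1.7-fold higher number from compound 1 to compound 4 (0.24 log units; within the scatter), so this pair shows no readable effect of moving the methoxy group. The change from 4-chlorophenyl to 2-methoxyphenyl gives a 1.3-fold higher number from compound 3 to compound 4 (0.12 log units; within the scatter), leaving compounds 1, 3 and 4 unseparated at this position, while a 6.3-fold higher number from compound 2 to compound 4 (0.80 log units; beyond the scatter) adds to the steps that set compound 2, with its 4-methylphenyl, apart from each of the other three. The data on hand give no measured basis for explaining these differences.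

Going by these compounds alone, with only one compound standing apart, it remains open whether its lower number is specific to the methyl group or would extend to a longer chain such as ethyl or propyl on the same ring. As far as these compounds go, how an amine or a carboxylic acid on that ring would compare with the methyl, methoxy and chloro analogues also remains open.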